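Swapping the aryl on the carbonyl of compound 3

The source may hold more compounds than are shown below. What is called first, only, known or untested is meant among the compounds shown, and "the series" means these compounds.

Compound 2 `Nc1nc(Nc2ccc(S(N)(=O)=O)cc2)sc1C(=O)c1cccnc1`: 2800 nM
Compound 3 `Nc1nc(Nc2ccc(S(N)(=O)=O)cc2)sc1C(=O)c1ccccc1[N+](=O)[O-]`: 300 nM

In a functional assay on MDA-MB-468 cells (Homo sapiens) for cytotoxicity, read by MTT assay, with a stated time of 72 h (on this read-out lower numbers stand for stronger inhibition and higher numbers for weaker inhibition), compound 3 gives the lowest of the two numbers; compound 2 gives the next, and compound 1 `Nc1nc(Nc2ccccc2)sc1C(=O)c1cccc(F)c1` has no number reported, its entry being "not determined" (no result reported). Compound 4 `Nc1nc(Nc2ccc(S(N)(=O)=O)cc2)sc1C(=O)c1cccc(F)c1` differs from compound 3 by 3-fluorophenyl in place of 2-nitrophenyl on a carbonyl carbon. For the measured compounds named here, the one step that bears on this position is a 9.3-fold lower number from compound 2 to compound 3 (0.97 log units; beyond the scatter), which shows that changing the group on the carbonyl carbon can move the number by a modest amount. Nothing here shows how 3-fluorophenyl compares with 2-nitrophenyl, so compound 4 is expected to give a number somewhat higher than compound 3, a step of a 3.0-fold higher number from compound 3 to compound 4 (0.48 log units; beyond the scatter), with wide uncertainty. Compound 4 is estimated at 900 nM, between 250 nM and 3500 nM.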

Compound 4, half-maximal inhibitory concentration: 800 nM
Compound 4: middle estimate off by 1.1-fold (0.05 log units), on the high side; the range from low to high includes it.
By their numbers in this assay, from the lowest: compound 3; then compound 4; then compound 2.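

In this assay a third group now sits on the carbonyl carbon, and 3-fluorophenyl falls in the middle: there is a 2.7-fold higher number from compound 3 to compound 4 (0.43 log units; beyond the scatter) but also a 3.5-fold lower number from compound 2 to compound 4 (0.54 log units; beyond the scatter). Both rings of carbon only therefore give lower numbers than pyridin-3-yl, with 2-nitrophenyl lowest of the three. Nothing measured here explains this order.

From the compounds shown here alone, whether a plain phenyl, or a ring carrying an amine or a carboxylic acid, would fall below compound 3 stays open. With no number for compound 1, the sulfonamide's contribution also cannot be judged.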